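Methyl capping of the phenol in a pyrazole series

The source may hold more compounds than are shown below. What is called first, only, known or untested is meant among the compounds shown, and "the series" means these compounds.

Measured compounds:
- compound 1, `O=C(Nc1cccc(-n2cc(-c3ccncc3)c(-c3cc(O)cc(Cl)c3)n2)c1)Nc1ccc(Cl)c(C(F)(F)F)c1`: 32.6%
- compound 2, `COc1cc(Cl)cc(-c2nn(-c3cccc(NC(=O)c4cccc(C(F)(F)F)c4)c3)cc2-c2ccncc2)c1`: 64.2%
- compound 3, `O=C(Nc1cccc(-n2cc(-c3ccncc3)c(-c3cc(O)cc(Cl)c3)n2)c1)c1cc(C(F)(F)F)cc(C(F)(F)F)c1`: 75.5%

Three compounds sharing one core were tested in a functional assay on SF-539 cells (Homo sapiens) for inhibition, read by sulforhodamine B assay, with a stated time of 48 h, tested at 10 uM; on this read-out lower numbers stand for a stronger effect and higher numbers for a weaker effect at the one concentration tested. Compound 1 gives 32.6%, compound 2 gives 64.2%, and compound 3 gives 75.5%. Compound 3 therefore shows the highest number of the three, meaning the weakest effect; compound 2 lies nearest to it, by a gap beyond the scatter, and compound 1 lies furthest away, also beyond the scatter. No two of these compounds differ in only one place, so no single change can be read directly from them.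

Compound 4, `COc1cc(Cl)cc(-c2nn(-c3cccc(NC(=O)c4cc(C(F)(F)F)cc(C(F)(F)F)c4)c3)cc2-c2ccncc2)c1`, differs from compound 3 in one spot: methyl in place of hydrogen on an oxygen on an aromatic ring. Nothing measured here isolates this change, so the direction is uncertain. Compound 2, which carries the same methoxy group, gives 64.2%, somewhat lower than compound 3, which hints at a modest move downward. The expected step of a number 4.5 percentage points lower from compound 3 to compound 4 (within the scatter) is small, within or near the scatter. Compound 4 is estimated at 71%, with a range from 54% to 88%.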

Compound 4, a percentage reported as activity, at one concentration (the size of the read-out at that concentration, not a potency): 80%
Beside the measured number, compound 4's estimate is 9 percentage points below it, within the range that was stated.
By their numbers in this assay, from the lowest: compound 1; then compound 2; then compounds 3 and 4 (each within the scatter of the next).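

In this assay, the step from hydroxy to methoxy on the 3-chloro-5-hydroxyphenyl group is a number 4.5 percentage points higher from compound 3 to compound 4 (within the scatter), so capping this oxygen with a methyl leaves no difference that can be told from scatter in this setting. The other step, a number 15.8 percentage points higher from compound 2 to compound 4 (beyond the scatter), goes with trifluoromethyl in place of hydrogen on an aromatic carbon, and it shows a weaker effect at the one concentration tested, away from the capped oxygen. No measurement shown here explains either step.

On these data alone, whether the methyl cap would read the same way in the setting of compound 1 or compound 2 stays open. So does whether a longer chain such as ethyl on that oxygen, or an amine in place of the hydroxy, would shift the number.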